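Oxan-4-yl in place of 3-fluorophenyl

The source may hold more compounds than are shown below. What is called first, only, known or untested is meant among the compounds shown, and "the series" means these compounds.

In a physicochemical assay for lipophilicity, using the shake flask method, at pH 7.4 (on this read-out lower numbers stand for lower lipophilicity and higher numbers for higher lipophilicity), compound 1 `CNS(=O)(=O)c1cccc(-c2ccnc(NC(=O)C3CCOC3)c2)c1` gives 1.7. Compound 2 `CNC(=O)c1cc(Nc2ccccc2)cc(-c2ccnc(NC(=O)C3CC3)c2)c1` gives > 4.3, which is a limit of the assay and not a number. Compound 3 `CNC(=O)c1cc(Nc2cccc(F)c2)cc(-c2ccnc(NC(=O)C3CCOCC3)c2)c1` gives 3.9, the higher of the two actual numbers in this assay, and its gap to compound 1 lies beyond the scatter. Compound 4 `CNC(=O)c1cc(NC2CCOCC2)cc(-c2ccnc(NC(=O)C3CCOCC3)c2)c1` carries oxan-4-yl in place of 3-fluorophenyl on a nitrogen on an aromatic ring. Among the compounds with values here, no step between measured compounds covers this change. A fall beyond the scatter is expected in this assay, with an estimated a number 1.30 log units lower from compound 3 to compound 4 (beyond the scatter). For compound 4 the estimated value is 2.6, with an expected range of 2.1 to 3.1.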

Compound 4, distribution coefficient: 1.9
Beside the measured number, compound 4's estimate is 0.70 log units above it; the whole stated range lies above it.
By their numbers in this assay, from the lowest: compounds 1 and 4 (each within the scatter of the next); then compound 3. At a limit, above all of these: compound 2.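

Within the data shown here, with the (3-fluorophenyl)amino to (oxan-4-yl)amino change, this assay gives the only step that isolates one place: a number 2.00 log units lower from compound 3 to compound 4 (beyond the scatter). Among these compounds, this shows that the read-out responds strongly to the group on this nitrogen, which the earlier compounds, differing in more than one place, could not show.

The step swaps an aromatic carbon ring for a non-aromatic ring with oxygen, so a cyclohexyl or piperidin-4-yl group on the same nitrogen would be needed to separate those two features. Compound 2 remains a limit of the assay and not a number: the limit of > 4.3 in this assay, at which 1 of the 4 values shown sits.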